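The source may report more compounds than this note shows. Statements on the series, on what has been measured and on what is new or still open speak of the compounds shown alone.

Working notes on the series, read in a functional assay on KYSE-450 cells (Homo sapiens) for inhibition, read by MTT assay, with a stated time of 48 h; a lower number here means a stronger inhibitor, a higher number a weaker inhibitor. Compound 1 (`C/C=C/C(=O)N(Cc1ccc(OC)c(N)c1)c1cc(OC)c(OC)c(OC)c1`) gives 310 nM, compound 3 (`C/C=C/C(=O)N(Cc1ccc(OC)c(Br)c1)c1cc(OC)c(OC)c(OC)c1`) gives 10500 nM, and compound 2 (`COc1cc(NCc2cccc(O)c2)cc(OC)c1OC`) gives 71300 nM. Compound 3 therefore holds the second highest of the three numbers. Compound 4 (`C/C=C/C(=O)N(Cc1cccc(O)c1)c1cc(OC)c(OC)c(OC)c1`) is next, with this change from compound 3: 3-hydroxyphenyl in place of 3-bromo-4-methoxyphenyl on a saturated chain carbon bound to an amide-type nitrogen. In words, 3-hydroxyphenyl stands in place of 3-bromo-4-methoxyphenyl on a saturated chain carbon bound to an amide-type nitrogen.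

For the measured compounds named here, one measured step bears on this group: a 34-fold higher number from compound 1 to compound 3 (1.53 log units; beyond the scatter), a large step with bromo in place of amino on an aromatic carbon. Going by the values given here, it shows that a single exchange on this group can shift the number widely, but no measured step covers the exact change to compound 4. Compound 2 also carries 3-hydroxyphenyl, but it differs elsewhere and gives only indirect guidance. A moderate move towards a lower number is expected, with wide uncertainty, and the expected step is a 2.6-fold lower number from compound 3 to compound 4 (0.42 log units; beyond the scatter). Compound 4 is estimated at 4000 nM, with an expected range from 800 nM to 20000 nM.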

Compound 4, half-maximal inhibitory concentration: 14700 nM
Estimate against measurement, compound 4: 3.7-fold (0.57 log units) below, within the range that was stated.
By their numbers in this assay, from the lowest: compound 1; then compounds 3 and 4 (each within the scatter of the next); then compound 2.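

In this assay, the exchange at this position gives a 1.4-fold higher number from compound 3 to compound 4 (0.15 log units; within the scatter), so 3-hydroxyphenyl and 3-bromo-4-methoxyphenyl on a saturated chain carbon bound to an amide-type nitrogen read alike, and losing the bromo and methoxy groups together leaves the number where it was. The amino compound stays well apart, with a 47-fold higher number from compound 1 to compound 4 (1.68 log units; beyond the scatter), so of the three aromatic groups with the acylated nitrogen only 3-amino-4-methoxyphenyl gives a low number. For the compounds shown here, with 3-hydroxyphenyl held constant, (prop-1-en-1-yl)carbonyl in place of hydrogen on a nitrogen on an aromatic ring gives a 4.9-fold lower number from compound 2 to compound 4 (0.69 log units; beyond the scatter), a modest step and the only measured reading of that exchange here.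

No supporting data accompany these steps to explain them. Going by these compounds, whether the number of compound 1 depends on the amino group alone or on the amino and methoxy groups together stays open; 3-aminophenyl and 3-hydroxy-4-methoxyphenyl on the same chain carbon would separate the two.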